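Dimethylamino in place of bromo on compound 1

This account rests on a few compounds, and the source may have more. Where it says the series, first, only, none or still open, it means among the compounds named here.

Compound 1 (`COc1ccc(C(=O)c2ccc(OC)c3c2OC(C)(C)C=C3)c(NC(=O)CBr)c1`) gives 980 nM
Compound 2 (`COc1ccc(C(=O)c2ccc(OC)c3c2C=CC(C)(C)O3)c(NC(=O)CN)c1`) gives 890 nM
Compound 3 (`CNCC(=O)Nc1cc(OC)ccc1C(=O)c1ccc2c(c1)C=CC(C)(C)O2`) gives 850 nM

All three values come from a functional assay on A2780 cells (Homo sapiens) for antiproliferative activity, read by MTT assay, with a stated time of 48 h (on this read-out higher numbers stand for weaker inhibition and lower numbers for stronger inhibition), and lie within the scatter of one another, so compound 1 stands level with the other two. Compound 4 (`COc1ccc(C(=O)c2ccc(OC)c3c2OC(C)(C)C=C3)c(NC(=O)CN(C)C)c1`) keeps the core of compound 1 and changes one group (dimethylamino in place of bromo on a saturated chain carbon bound to a carbonyl carbon), with dimethylamino in place of bromo on a saturated chain carbon bound to a carbonyl carbon. Among the compounds with values here, no measured pair shows this change alone. Compound 2 (890 nM) and compound 3 (850 nM) both differ from compound 1 (980 nM) in more than one place, yet remain within the scatter of it. The expected step (a 1.2-fold lower number from compound 1 to compound 4 (0.09 log units; within the scatter)) is therefore none beyond the scatter. Compound 4 is estimated at 800 nM (range 320 nM to 2000 nM).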

Compound 4, half-maximal inhibitory concentration: 790 nM
The estimate for compound 4 lay 1.0-fold (0.01 log units) above the measured number; the measured number falls inside the stated range.
By their numbers in this assay, from the lowest: compounds 4, 3, 2 and 1 (each within the scatter of the next).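

In this assay the direct step for dimethylamino in place of bromo reads a 1.2-fold lower number from compound 1 to compound 4 (0.09 log units; within the scatter) and thus places the two compounds level, on the core of compound 1 and at this saturated chain carbon bound to a carbonyl carbon. Within the data shown here, this single change, which the earlier compounds could not isolate, leaves the antiproliferative reading in these cells unmoved. Nothing at hand gives a reason for this result.
Still open, from the compounds shown here alone, is whether a morpholine, a carboxylic acid or a longer chain at this place would also stand level with compound 1 and compound 4.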